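The source may report more compounds than this note shows. Statements on the series, on what has been measured and on what is new or still open speak of the compounds shown alone.

Measured compounds:
compound 1 `c1ccc(C2=NN(C3=NC(c4ccccc4)CS3)C(c3cccc4ccccc34)C2)cc1` gives 14300 nM in a functional assay on BGC-823 cells (Homo sapiens) for inhibition, read by CCK-8 assay, with a stated time of 48 h; on this read-out higher numbers stand for weaker inhibition and lower numbers for stronger inhibition;
compound 2 `Cc1ccc(C2=NN(C3=NC(c4ccccc4)CS3)C(c3ccc4ccccc4c3)C2)cc1` gives 8940 nM in this assay.

Compound 2 thus stands beside compound 1, the two numbers lying within the usual scatter of each other, so neither can be set above the other. Compound 3 `Cc1ccc(C2=NN(C3=NC(=O)CS3)C(c3ccc4ccccc4c3)C2)cc1` has not yet been measured in this assay. It differs from compound 2 in one place: a group of 6 heavy atoms (3 carbon, 1 nitrogen, 1 oxygen, 1 sulfur; one five-membered non-aromatic ring with 2 hetero atoms) in place of a group of 11 heavy atoms (9 carbon, 1 nitrogen, 1 sulfur; one five-membered non-aromatic ring with 2 hetero atoms, one six-membered aromatic ring of carbon only), on an amine nitrogen in a ring. No measured pair shows a change of this kind, so its effect is unknown from the data shown. Both measured compounds sit in the weak range, and the change removes a sizeable part of the molecule; compound 3 is expected to land near compound 2 or somewhat higher, with a 1.8-fold higher number from compound 2 to compound 3 (0.25 log units; within the scatter) as the estimated step. For compound 3 the expected value is 16000 nM, in a range from 5000 nM to 50000 nM.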

Compound 3, half-maximal inhibitory concentration: 7790 nM
Estimate against measurement, compound 3: 2.1-fold (0.31 log units) above; the range from low to high includes it.
By their numbers in this assay, from the lowest: compounds 3, 2 and 1 (each within the scatter of the next).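

On the amine nitrogen in a ring, a group of 6 heavy atoms can stand in place of a group of 11 heavy atoms in this assay with no reading beyond the scatter: a 1.1-fold lower number from compound 2 to compound 3 (0.06 log units; within the scatter). The six-membered aromatic ring of carbon only in the group that leaves is therefore not required for the level of inhibition seen with compound 2, and the position tolerates a much smaller group, although compound 3 remains in the same weak range. Nothing in the data shown accounts for this result.

Going by these compounds, it remains open whether any group at this nitrogen can lift inhibition out of the weak range. An amine or a carboxylic acid carried on the five-membered ring of compound 3 would test this.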